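This account rests on a few compounds, and the source may have more. Where it says the series, first, only, none or still open, it means among the compounds named here.

Three compounds share one core and were tested in a functional assay on U-87MG ATCC cells for antiproliferative activity against U-87 MG (Homo sapiens), read by MTT assay, with a stated time of 48 h, tested at 5 uM; on this read-out higher numbers stand for a weaker effect at the one concentration tested and lower numbers for a stronger effect. Compound 1 `COc1ccc(-c2nc(C)c(C(=O)CSc3nc(-c4ccc(OC)cc4)c(C#N)c(=O)[nH]3)s2)cc1` gives 97%, compound 2 `Cc1nc(-c2ccc(Cl)cc2)sc1C(=O)CSc1nc(-c2ccc(Cl)c(Cl)c2)c(C#N)c(=O)[nH]1` gives 101%, and compound 3 `Cc1nc(-c2ccc(Cl)cc2)sc1C(=O)CSc1nc(-c2cccc(Cl)c2)c(C#N)c(=O)[nH]1` gives 80.2%, the lowest of the three numbers and therefore the strongest effect seen so far. Going by the values given here, the only single-point step measured is a number 20.8 percentage points lower from compound 2 to compound 3 (beyond the scatter), a modest change in the direction of a stronger effect.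

Compound 4 `COc1ccc(-c2nc(SCC(=O)c3sc(-c4ccc(Cl)cc4)nc3C)[nH]c(=O)c2C#N)cc1` has not been measured. It differs from compound 3 by 4-methoxyphenyl in place of 3-chlorophenyl on an aromatic carbon. Among the compounds with values here, no measured step covers this change directly. Within the data shown here, the one compound that carries a 4-methoxyphenyl at this place, compound 1, shows a number near the top of the range, while compound 3 with 3-chlorophenyl sits at the bottom; the two also differ elsewhere, so this comparison is only a hint. On that basis a move back toward a weaker effect is expected, of about a number 11.8 percentage points higher from compound 3 to compound 4 (beyond the scatter), and compound 4 is estimated at 92%, within 74% to 108%.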

Compound 4, a percentage reported as activity, at one concentration (the size of the read-out at that concentration, not a potency): 92.1%
The estimate for compound 4 lay 0.1 percentage points below the measured number; low and high end bracket the measured number.
By their numbers in this assay, from the lowest: compound 3; then compounds 4, 1 and 2 (each within the scatter of the next).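

In this assay, the group at this place now has a step in which nothing else changes: a number 11.9 percentage points higher from compound 3 to compound 4 (beyond the scatter), so 4-methoxyphenyl in place of 3-chlorophenyl gives a weaker effect. With 4-methoxyphenyl in place of 3,4-dichlorophenyl the result is a number 8.9 percentage points lower from compound 2 to compound 4 (within the scatter), and with chloro in place of methoxy on an aromatic carbon elsewhere it is a number 4.9 percentage points lower from compound 1 to compound 4 (within the scatter); among the three groups tried at this place on an otherwise identical molecule, only 3-chlorophenyl stands apart, and the methoxy-to-chloro swap shows no change that can be told from scatter. Nothing measured here explains why 3-chlorophenyl behaves differently.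

From the compounds shown here alone, how an unsubstituted phenyl would compare at this place remains open. So does whether a ring carrying an amine or a carboxylic acid would give a stronger effect than compound 3 with 80.2%.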